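A few compounds are considered here, and "the series" means these few. Any claim that something is new, unique, unknown or untested is made for them only; others in the source may bear on it.

Compound 1 `CN(C)CCCCOc1ccccc1/C=C/c1cccc(Cl)c1`: 14.3%
Compound 2 `C(=C/c1ccccc1OCCCCN1CCCCC1)\c1ccccc1`: 42.9%
Compound 3 `CN1CCN(CCCCOc2ccccc2/C=C/c2ccccc2F)CC1`: 0%

In a functional assay on the whole organism with Mus musculus as the target, in the maximal electroshock model, at a dose of 50 mg/kg by the oral route (a higher number here means more inhibition at the dose given (going by the name of the read-out), a lower number less inhibition), compound 2 stands highest of the three numbers shown; compound 1 lies nearest, with a number lower by more than the scatter, and compound 3 lies furthest, also beyond the scatter. Compound 4 `NC(=O)C1CCCN(CCCCOc2ccccc2/C=C/c2ccccc2)C1` has not yet been tested in this assay. It differs from compound 2 in one place: carbamoyl in place of hydrogen on a saturated ring carbon. Among the measured compounds shown here, no measured pair shows this change, so no measured step tells its size. The three numbers shown already vary widely, and any expectation for compound 4 must carry a wide band. From compound 2 the step is expected to be a number 14.3 percentage points lower from compound 2 to compound 4 (beyond the scatter), a modest move downward. Compound 4 is expected to give 28.6% in this assay, between 0% and 57.1%.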

Compound 4, a percentage reported as inhibition, in the whole organism at one dose (the size of the read-out at that dose, not a potency): 0%
The estimate for compound 4 lay 28.6 percentage points above the measured number, within the range that was stated.
By their numbers in this assay, from the lowest: compounds 3 and 4 (each within the scatter of the next); then compound 1; then compound 2.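

In this assay, among the compounds shown here, the change from piperidin-1-yl to 3-carbamoylpiperidin-1-yl gives the only step measured at a single place, a number 42.9 percentage points lower from compound 2 to compound 4 (beyond the scatter). This shows that the saturated ring carbon two ring bonds from the ring nitrogen is not a neutral site for carbamoyl at this dose. No available evidence accounts for the loss. From the compounds shown here alone, it remains open whether a methyl or hydroxyl group on the same ring carbon, or a carboxylic acid in place of carbamoyl, would retain the inhibition seen with compound 2. Going by these compounds, whether carbamoyl on another ring carbon would behave alike is also open.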